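Aryl substituent swap at the thiosemicarbazone end: methoxy to dimethylamino

The source may report more compounds than this note shows. Statements on the series, on what has been measured and on what is new or still open speak of the compounds shown alone.

Compound 3 `COc1ccc(/C=N\NC(=S)NC(C)(C)CCC[C@](C)(O)[C@@H]2CC=C(C)CC2)cc1` gives 34900 nM in a functional assay on K562 cells (Homo sapiens) for cytotoxicity, read by sulforhodamine B assay (on this read-out lower numbers stand for stronger inhibition of growth and higher numbers for weaker inhibition of growth), the highest of the three numbers. Compound 1 `CC1=CC[C@@H]([C@@](C)(O)CCCC(C)(C)NC(=S)N/N=C\c2ccccc2)CC1` gives 20900 nM in this assay, and the step of a 1.7-fold higher number from compound 1 to compound 3 (0.22 log units; within the scatter) lies within the scatter. Compound 2 `CC1=CC[C@@H]([C@@](C)(O)CCCC(C)(C)NC(=S)N/N=C\c2ccc(C)cc2)CC1` gives 7950 nM in this assay, so the step of a 4.4-fold higher number from compound 2 to compound 3 (0.64 log units; beyond the scatter) is beyond the scatter. Compound 4 `CC1=CC[C@@H]([C@@](C)(O)CCCC(C)(C)NC(=S)N/N=C\c2ccc(N(C)C)cc2)CC1` differs from compound 3 by dimethylamino in place of methoxy on an aromatic carbon. For the measured compounds named here, the steps that bear on this change are a 1.7-fold higher number from compound 1 to compound 3 (0.22 log units; within the scatter) and a 4.4-fold higher number from compound 2 to compound 3 (0.64 log units; beyond the scatter), both at the same aromatic carbon and both modest at most. Going by the values given here, no measured step concerns dimethylamino, so a modest move in this assay, if any, is expected. Compound 4 is estimated at 20000 nM, with a range from 6000 nM to 65000 nM. This corresponds to an expected step of a 1.7-fold lower number from compound 3 to compound 4 (0.24 log units; within the scatter).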

Compound 4, concentration for total growth inhibition: 42000 nM
The estimate for compound 4 lay 2.1-fold (0.32 log units) below the measured number; the range from low to high includes it.
By their numbers in this assay, from the lowest: compound 2; then compounds 1, 3 and 4 (each within the scatter of the next).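

In this assay dimethylamino at this aromatic carbon does not separate from methoxy (a 1.2-fold higher number from compound 3 to compound 4 (0.08 log units; within the scatter)) or from hydrogen (a 2.0-fold higher number from compound 1 to compound 4 (0.30 log units; within the scatter)). Methyl does separate from it (a 5.3-fold higher number from compound 2 to compound 4 (0.72 log units; beyond the scatter)), which leaves compound 2 as the only compound whose steps to all three others lie beyond the scatter. No evidence is available to explain this difference. As far as these compounds go, whether the advantage is particular to methyl or extends to ethyl or to chlorine at the same carbon stays open.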